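A few compounds are considered here, and "the series" means these few. Any claim that something is new, unique, unknown or untested is made for them only; others in the source may bear on it.

Working notes on the series. Compound 1 `C=CC1=C(C(=O)NCc2ccccc2)C(c2ccc(Cl)c(Cl)c2)OC1` and compound 2 `C=CC1=C(C(=O)NCCC)C(c2ccc(OC)c(OC)c2)OC1` share the same core and differ only in the amide substituent and the aryl ring. In a functional assay on SW480 cells (Homo sapiens) for cytotoxicity, read by MTT assay, with a stated time of 24 h (a higher number here means a weaker inhibitor, a lower number a stronger inhibitor), compound 1 gives > 100000 nM, which is a limit of the assay rather than a number. Compound 2 also reaches only a limit in this assay, namely > 100000 nM. Compound 1 therefore stands at the limit, where (the limit of > 100000 nM in this assay, at which 2 of the 2 values shown sit). Compound 3 `C=CC1=C(C(=O)NCCCCC)C(c2ccc(Cl)c(Cl)c2)OC1` is the next compound to be tested; it differs from compound 1 by butyl in place of phenyl on a saturated chain carbon bound to an amide-type nitrogen. For the measured compounds named here, no step between two measured compounds is available, so the size of this change cannot be read from any measurement. No movement beyond the scatter is expected because of the limit of > 100000 nM in this assay, at which 2 of the 2 values shown sit. The estimated step is a step that the limit leaves unreadable from compound 1 to compound 3, expected to be no change. Compound 3 is estimated at 150000 nM, with an expected range from 50000 nM to 500000 nM.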

Compound 3, half-maximal inhibitory concentration: 27500 nM
Compound 3: the middle estimate sits 5.5-fold (0.74 log units) above what was measured, and the stated range ends above it.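

Butyl in place of phenyl on a saturated chain carbon bound to an amide-type nitrogen gives the first value in this assay that is a number rather than a limit, with an at least 3.6-fold lower number from compound 1 to compound 3 (0.56 log units; beyond the scatter). With the rest of the structure unchanged, this place on the amide substituent can therefore move the read-out beyond the scatter, which neither earlier compound could show. The printed step is only a minimum, because compound 1 stands at a limit and not at a number: the limit of > 100000 nM in this assay, at which 2 of the 3 values shown sit.

From the compounds shown here alone, whether the shift follows from the loss of the aromatic ring or from the chain itself remains open, and a longer chain such as octyl, or a chain ending in an amine or a carboxylic acid, could separate the two. Also open, going by these compounds, is whether the pentylamino group gives a similar shift with the aryl ring of compound 2.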